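The source may hold more compounds than are shown below. What is called first, only, known or untested is meant among the compounds shown, and "the series" means these compounds.

Measured so far:
compound 1 `CC(C)(C)OC(=O)N1CCC(O[C@H]2CC[C@H](Oc3ccc(S(C)(=O)=O)cc3)CC2)CC1`: 120% in a functional assay on isolated protein for agonist activity at Glucose-dependent insulinotropic receptor (Rattus norvegicus), read by HTRF and cAMP accumulation; on this read-out higher numbers stand for larger maximal responses and lower numbers for smaller maximal responses
compound 2 `CC(C)(C)OC(=O)N1CCC(O[C@H]2CC[C@H](Oc3ccc(S(C)(=O)=O)cn3)CC2)CC1`: 108% in this assay

Going by the values given here, compound 2 stands lowest of these two numbers; its only neighbour is compound 1, and the step of a number 12 percentage points lower from compound 1 to compound 2 (beyond the scatter) lies beyond the usual scatter. Compound 3 `CC(C)(C)OC(=O)N1CCC(O[C@H]2CC[C@H](Oc3cnc(S(C)(=O)=O)cn3)CC2)CC1` is not yet measured and differs from compound 2 in one place: 5-(methylsulfonyl)pyrazin-2-yl in place of 5-(methylsulfonyl)pyridin-2-yl on an oxygen on a saturated carbon. Among the compounds with values here, the one measured step that bears on this, a number 12 percentage points lower from compound 1 to compound 2 (beyond the scatter), was modest and downward when 5-(methylsulfonyl)pyridin-2-yl replaced 4-(methylsulfonyl)phenyl, so a step of a number 8 percentage points lower from compound 2 to compound 3 (within the scatter) in this assay is expected, small and downward or none beyond the scatter. Compound 3 is therefore estimated at 100%, between 85% and 115%.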

Compound 3, largest response reached (Emax), in percent of the reference or control that the assay uses: 110%
The estimate for compound 3 lay 10 percentage points below the measured number; the range from low to high includes it.
By their numbers in this assay, from the lowest: compounds 2, 3 and 1 (each within the scatter of the next, the first and the last beyond it).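

Going from one to two hetero atoms in the aromatic ring on the oxygen gives a number 2 percentage points higher from compound 2 to compound 3 (within the scatter) in this assay, so at this position the added ring nitrogen brings no readable change. Replacing 4-(methylsulfonyl)phenyl with 5-(methylsulfonyl)pyrazin-2-yl gives a number 10 percentage points lower from compound 1 to compound 3 (within the scatter), so the step beyond the scatter seen with the pyridine does not recur with the pyrazine. No evidence is available to explain these numbers. Going by these compounds, all three compounds keep the methylsulfonyl group, so the effect of a carboxylic acid or an amine in its place remains open.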